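Benzyl Extension on the Indole Nitrogen of Compound 2

This account rests on a few compounds, and the source may have more. Where it says the series, first, only, none or still open, it means among the compounds named here.

Compound 2 `Cn1cc(-c2coc(-c3ccc(Cl)cc3)n2)c2ccccc21` gives the highest of the two numbers measured in a functional assay on PC-3 cells (Homo sapiens) for cytotoxicity, read by MTT assay, with a stated time of 48 h (a lower number here means a stronger inhibitor, a higher number a weaker inhibitor), at 302000 nM; its nearest neighbour is compound 1 `Clc1ccc(-c2nc(-c3c[nH]c4ccccc34)co2)cc1`, which in this assay gives 151000 nM. Going by the values given here, the only measured step, a 2.0-fold higher number from compound 1 to compound 2 (0.30 log units; within the scatter), lies within the scatter. Compound 3 `Clc1ccc(Cn2cc(-c3coc(-c4ccc(Cl)cc4)n3)c3ccccc32)cc1` differs from compound 2 by 4-chlorophenyl in place of hydrogen on a saturated chain carbon bound to an aromatic nitrogen. Among the compounds with values here, no measured step bears directly on this larger change, and the one related step was flat, so no shift beyond the scatter is expected for compound 3, a 1.5-fold lower number from compound 2 to compound 3 (0.18 log units; within the scatter). Compound 3 is therefore estimated at 200000 nM, within 50000 nM to 600000 nM.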

Compound 3, half-maximal inhibitory concentration: 350000 nM
The estimate for compound 3 lay 1.8-fold (0.24 log units) below the measured number, and the stated range covers the measured number.
By their numbers in this assay, from the lowest: compounds 1, 2 and 3 (each within the scatter of the next, the first and the last beyond it).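

In this assay, going from methyl to 4-chlorobenzyl on the aromatic nitrogen adds a whole 4-chlorophenyl, yet the step stays within the scatter, a 1.2-fold higher number from compound 2 to compound 3 (0.06 log units; within the scatter). Going by these compounds alone, measured against hydrogen on that nitrogen, the same group gives the only step here beyond the scatter, and a modest one, a 2.3-fold higher number from compound 1 to compound 3 (0.37 log units; beyond the scatter), with the number rising rather than falling. So far, no substituent at this position has lowered the number.

Going by these compounds, whether an amine, a carboxylic acid or a longer chain in place of the 4-chlorobenzyl would lower it stays open. No evidence at hand explains these steps.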